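The source may hold more compounds than are shown below. What is called first, only, known or untested is meant among the compounds shown, and "the series" means these compounds.

In a functional assay on HepG2 cells (Homo sapiens) for antiproliferative activity, read by MTT assay, with a stated time of 24 h (a higher number here means a weaker inhibitor, a lower number a stronger inhibitor), compound 1 `c1ccc(C2=NN(c3ccc(-c4ccccc4)nn3)C(c3ccccc3)C2)cc1` gives 10000 nM. Compound 3 `Clc1ccc(C2=NN(c3ccc(-c4ccccc4)nn3)C(c3ccccc3)C2)cc1`, which carries a chloro in place of a hydrogen on one aromatic carbon, gives 8750 nM, and the step of a 1.1-fold lower number from compound 1 to compound 3 (0.06 log units; within the scatter) is small. Compound 2 `COc1ccc(C2CC(c3ccccc3)=NN2c2ccc(-c3ccccc3)nn2)cc1` reaches only the limit of this assay at > 100000 nM. Placing a methoxy instead of a hydrogen on an aromatic carbon therefore gives the step of an at least 10-fold higher number from compound 1 to compound 2 (1.00 log units; beyond the scatter), so that one of the three results sits at the limit of > 100000 nM in this assay, at which 1 of the 3 values shown sits. Among the two numbers shown, compound 3 holds the lowest, with compound 1 close by and within the usual scatter.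

Compound 4 `FC(F)(F)c1ccc(C2CC(c3ccc(Cl)cc3)=NN2c2ccc(-c3ccccc3)nn2)cc1` departs from compound 3 by trifluoromethyl in place of hydrogen on an aromatic carbon. Among the measured compounds shown here, two measured steps bear on this change: the small chloro step and the large methoxy step, the latter made at the same kind of place on the ring that now receives the trifluoromethyl. A higher number than that of compound 3 is expected for compound 4, though not necessarily all the way to the limit, so the step of a 2.9-fold higher number from compound 3 to compound 4 (0.46 log units; beyond the scatter) is estimated. Compound 4 is therefore expected to give about 25000 nM, likely between 8000 nM and 100000 nM.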

Compound 4, half-maximal inhibitory concentration: 8330 nM
The estimate for compound 4 lay 3.0-fold (0.48 log units) above the measured number; low and high end bracket the measured number.
By their numbers in this assay, from the lowest: compounds 4, 3 and 1 (each within the scatter of the next). At a limit, above all of these: compound 2.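

In this assay, trifluoromethyl in place of hydrogen on this ring, para to a large group, gives a 1.1-fold lower number from compound 3 to compound 4 (0.02 log units; within the scatter), so this step stays within the scatter. A new group at this place therefore does not in itself raise the number, which the methoxy step alone could not show. That methoxy step, however, was made on compound 1 and this one on compound 3, so the two steps start from parents that differ by a chloro, and compound 2 remains a limit rather than a number: the limit of > 100000 nM in this assay, at which 1 of the 4 values shown sits.

From the compounds shown here alone, it remains open whether methoxy would give so large a step on compound 3 as well, so the contrast between the two groups is not settled. Going by these compounds, how an amine, a carboxylic acid or a longer chain would read at this position also stays open.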